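Nitro to trifluoromethyl on compound 2

A few compounds are considered here, and "the series" means these few. Any claim that something is new, unique, unknown or untested is made for them only; others in the source may bear on it.

Values in a physicochemical assay for lipophilicity; on this read-out lower numbers stand for lower lipophilicity and higher numbers for higher lipophilicity:
- compound 1 `Oc1ccc(OC(=S)Nc2ccc(Oc3ccc(C(F)(F)F)cc3)cc2)cc1` gives 6.11
- compound 2 `O=[N+]([O-])c1ccc(Sc2ccc(NC(=S)Oc3ccc(O)cc3)cc2)cc1` gives 5.25
- compound 3 `CC(=O)Nc1ccc(OC(=S)Nc2ccc(Sc3ccc([N+](=O)[O-])cc3)cc2)cc1` gives 5.06

Compound 2 sits clearly under compound 1 and level with compound 3, the step being a number 0.19 log units lower from compound 2 to compound 3 (within the scatter). That step changes a different group, so it says little here. Compound 4 `Oc1ccc(OC(=S)Nc2ccc(Sc3ccc(C(F)(F)F)cc3)cc2)cc1` is compound 2 with one change: trifluoromethyl in place of nitro on an aromatic carbon. Going by the values given here, no measured step makes this exact swap. Compound 1 also carries trifluoromethyl and stands at 6.11, though its core differs from that of compound 2. It is an imperfect guide, but it points to an upward move in this assay, beyond the scatter. The expected step is a number 1.05 log units higher from compound 2 to compound 4 (beyond the scatter). For compound 4 the estimated value is 6.3, with an expected range from 5.8 to 6.8.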

Compound 4, partition coefficient: 6.66
Compound 4: middle estimate off by 0.36 log units, on the low side; the measured number falls inside the stated range.
By their numbers in this assay, from the lowest: compounds 3 and 2 (each within the scatter of the next); then compound 1; then compound 4.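

Swapping nitro for trifluoromethyl on an aromatic carbon, para to a large group, gives a number 1.41 log units higher from compound 2 to compound 4 (beyond the scatter) in this assay with the rest of the molecule unchanged. Going by these compounds alone, this is the first direct reading of this change at this position, since compound 1 carries trifluoromethyl on a different core and could only hint at the direction. No measurement shown here accounts for the size of the step.

As far as these compounds go, it remains open where an amine or a carboxylic acid at this position would fall in this assay relative to compound 2 and compound 4. From the compounds shown here alone, whether the same swap gives a similar step on the core of compound 1 also remains open.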